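Methoxyphenyl Amide Gives Way to a Dimethyl-oxazolyl Amide

The compounds below may be only part of what the source reports. "The series", "measured", "known", "first", "only" and "open" are said of these compounds alone.

Compound 1, `CSc1ccc2nc(C)cc(OCC(=O)Nc3cc(C)cc(C)c3)c2c1`: > 100000 nM
Compound 2, `COc1ccc2nc(C)cc(OC(C)C(=O)Nc3cc(C)cc(C)c3)c2c1`: 39800 nM
Compound 3, `COc1ccc(NC(=O)COc2cc(C)nc3ccc(OC)cc23)cc1`: > 100000 nM

In a toxicity assay on HepG2 cells (Homo sapiens) for inhibition, read by CellTiter-Glo, with a stated time of 48 h (a higher number here means a weaker inhibitor, a lower number a stronger inhibitor), compound 1 returns only a limit, > 100000 nM. Compound 3 likewise returns only a limit, > 100000 nM, so its standing among the three is known only as sitting at the limit of > 100000 nM in this assay, at which 2 of the 3 values shown sit. Within the data shown here, compound 2 is the one compound with a number, 39800 nM.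

Compound 4, `COc1ccc2nc(C)cc(OCC(=O)Nc3noc(C)c3C)c2c1`, has not been measured. It differs from compound 3 in one place: 4,5-dimethyl-1,2-oxazol-3-yl in place of 4-methoxyphenyl on an amide-type nitrogen. With compound 3 known only as a limit, the step is expected to be small, a number no higher from compound 3 to compound 4 (the limit leaves the size open), with no clear direction beyond the scatter. Compound 4 is therefore expected to give about 100000 nM, most likely again as a limit, within 40000 nM to 300000 nM.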

Compound 4, half-maximal inhibitory concentration: > 100000 nM
Compound 4: only a limit was reported; the forecaster's own chance of this, stated with the estimate: 70%; the middle value sits exactly at the limit.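

Compound 3 and compound 4 each return only a limit, so no step between them can be read: the limit of > 100000 nM in this assay, at which 3 of the 4 values shown sit.

The compounds shown leave open whether 4,5-dimethyl-1,2-oxazol-3-yl in place of 4-methoxyphenyl on an amide-type nitrogen changes the result in this assay at all.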